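The compounds below may be only part of what the source reports. "The series", "measured", "known", "first", "only" and "open" are said of these compounds alone.

- Compound 1 `O=C1Nc2c(C(F)(F)F)cccc2C1(c1ccc(O)cc1)N1CCC(F)(F)CC1` gives 35 nM
- Compound 2 `O=C1Nc2c(C(F)(F)F)cccc2[C@@]1(c1ccc(O)cc1)C1CCC(F)(F)CC1` gives > 1000 nM (a limit, not a number)
- Compound 3 `O=C1Nc2c(C(F)(F)F)cccc2C1(c1ccc(OC(F)(F)F)cc1)c1ccc(O)c(F)c1` gives 33 nM

All three were tested in a functional assay on MCF7 cells (Homo sapiens) for inhibition, read by resazurin assay, with a stated time of 24 h; on this read-out lower numbers stand for stronger inhibition and higher numbers for weaker inhibition. Compound 3 gives 33 nM and compound 1 gives 35 nM, so the two lie within the usual scatter of each other and cannot be ranked. Compound 2 is reported only as a limit (> 1000 nM) and has no exact value.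

Compound 4 `O=C1Nc2c(C(F)(F)F)cccc2C1(c1ccc(OC(F)(F)F)cc1)c1ccc(O)cc1F` has the same atoms as compound 3, joined differently: 2-fluoro-4-hydroxyphenyl in place of 3-fluoro-4-hydroxyphenyl on a saturated ring carbon. The change is 2-fluoro-4-hydroxyphenyl in place of 3-fluoro-4-hydroxyphenyl on a saturated ring carbon. For the measured compounds named here, no measured pair here differs in one place only, so the size of this step has no direct precedent. The starting point is therefore compound 3 at 33 nM, with a modest loss expected in this assay, possibly no larger than the scatter. The expected change is a 2.1-fold higher number from compound 3 to compound 4 (0.33 log units; beyond the scatter). For compound 4 the estimated value is 70 nM, with an expected range from 20 nM to 300 nM.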

Compound 4, half-maximal inhibitory concentration: 177 nM
Estimate against measurement, compound 4: 2.5-fold (0.40 log units) below; measured number inside the range.
By their numbers in this assay, from the lowest: compounds 3 and 1 (each within the scatter of the next); then compound 4. At a limit, above all of these: compound 2.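

In this assay, moving the fluorine within the hydroxyphenyl group is not a neutral swap: putting 2-fluoro-4-hydroxyphenyl in place of 3-fluoro-4-hydroxyphenyl on the saturated ring carbon gives a 5.4-fold higher number from compound 3 to compound 4 (0.73 log units; beyond the scatter), a step beyond the scatter. Both groups hold the same atoms, so this pair shows that the way those atoms are joined, and not only which atoms are present, can change the number on this core. Nothing shown here bears on why the 2-fluoro arrangement gives the weaker inhibition.

On these data alone, it remains open whether this loss is tied to fluorine itself, which a chlorine or a methyl group in its place could test. As far as these compounds go, it is also open whether a plain 4-hydroxyphenyl group, carrying no fluorine, would sit nearer compound 3 or compound 4.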